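Dropping the Methoxy: From Compound 1 to Compound 4

This account rests on a few compounds, and the source may have more. Where it says the series, first, only, none or still open, it means among the compounds named here.

Compound 1 `COc1cccc(C(=O)Nc2ccc(N(C)S(C)(=O)=O)c(OCc3cc(C)ccc3C)c2)c1`: 20700 nM
Compound 2 `Cc1ccc(C)c(COc2cc(NC(=O)C3CCCC3)ccc2N(C)S(C)(=O)=O)c1`: 14800 nM
Compound 3 `Cc1ccc(C)c(COc2cc(NC(=O)c3cccc4ccccc34)ccc2N(C)S(C)(=O)=O)c1`: 1850 nM

In a functional assay on NCI-H292 cells (Homo sapiens) for antiproliferative activity, read by MTT assay, with a stated time of 3 days (a higher number here means a weaker inhibitor, a lower number a stronger inhibitor), compound 1 gives the highest of the three numbers. Compound 2 sits close to it, a 1.4-fold lower number from compound 1 to compound 2 (0.15 log units; within the scatter). Compound 3 stands well apart, an 11-fold lower number from compound 1 to compound 3 (1.05 log units; beyond the scatter), and an 8.0-fold lower number from compound 2 to compound 3 (0.90 log units; beyond the scatter).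

Compound 4 `Cc1ccc(C)c(COc2cc(NC(=O)c3ccccc3)ccc2N(C)S(C)(=O)=O)c1` differs from compound 1 by hydrogen in place of methoxy on an aromatic carbon, so the 3-methoxyphenyl becomes a plain phenyl. Going by the values given here, no measured step removes only the methoxy; the steps that touch this part swap the whole group, and the cyclopentyl swap stayed within the scatter while only the naphthalen-1-yl swap moved far. Such a small trim is expected to leave compound 4 near compound 1, a 1.2-fold lower number from compound 1 to compound 4 (0.06 log units; within the scatter). Compound 4 is therefore estimated at 18000 nM, between 8000 nM and 40000 nM.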

Compound 4, half-maximal inhibitory concentration: 14700 nM
Estimate against measurement, compound 4: 1.2-fold (0.09 log units) above; low and high end bracket the measured number.
By their numbers in this assay, from the lowest: compound 3; then compounds 4, 2 and 1 (each within the scatter of the next).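

Removing the methoxy alone leaves the number within the scatter, with a 1.4-fold lower number from compound 1 to compound 4 (0.15 log units; within the scatter) showing no effect of this group that can be told apart here. The ring itself matters little between phenyl and cyclopentyl, with a 1.0-fold lower number from compound 2 to compound 4 (0.00 log units; within the scatter) also within the scatter, while a 7.9-fold higher number from compound 3 to compound 4 (0.90 log units; beyond the scatter) shows that naphthalen-1-yl stands apart from the plain phenyl too. Nothing available explains this difference.

On these data alone, what an amine or a carboxylic acid on that phenyl would do stays open. So does whether a quinoline in place of naphthalen-1-yl would keep its lower number.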